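This account rests on a few compounds, and the source may have more. Where it says the series, first, only, none or still open, it means among the compounds named here.

Measured in a functional assay on CHO cells for agonist activity at metabotropic glutamate receptor 2 (Homo sapiens), read by GTPgammaS binding; a higher number here means that more compound is needed for the effect, a lower number that less compound is needed:
Compound 1 `N#Cc1c(-c2ccc(NC3CCOCC3)c(Cl)c2)ccn2c(CC(F)(F)F)cnc12` gives 710 nM
Compound 2 `N#Cc1c(-c2ccc3c(c2)OCCN3)ccn2c(CC(F)(F)F)cnc12` gives 1660 nM

Compound 1 has the lower of the two numbers, and the gap to compound 2 lies beyond the scatter, so compound 1 needs less material for the effect. Compound 3 `N#Cc1c(-c2ccc(OC3CCOCC3)c(Cl)c2)ccn2c(CC(F)(F)F)cnc12` keeps the core of compound 1 and alters one group: (oxan-4-yl)oxy in place of (oxan-4-yl)amino on an aromatic carbon. Going by the values given here, no measured pair shows this kind of swap, so the expectation rests on compound 1 alone. The step in this assay is expected to be small, a 1.4-fold higher number from compound 1 to compound 3 (0.15 log units; within the scatter), leaning toward a slightly higher number. Compound 3 is therefore estimated at 1000 nM, within a range of 350 nM to 3000 nM.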

Compound 3, half-maximal effective concentration: 617 nM
Compound 3: middle estimate off by 1.6-fold (0.21 log units), on the high side; low and high end bracket the measured number.
By their numbers in this assay, from the lowest: compounds 3 and 1 (each within the scatter of the next); then compound 2.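

Swapping (oxan-4-yl)amino for (oxan-4-yl)oxy on the aromatic carbon ortho to a chloro group gives a 1.2-fold lower number from compound 1 to compound 3 (0.06 log units; within the scatter) in this assay. The leaving group has a hydrogen-bond donor and the entering group has none, so for this pair, the donor at this place is not needed to keep the number within the scatter. Still open, as far as these compounds go, is how a methylene link in place of the oxygen, or a piperidine ring in place of the oxan-4-yl ring, would read. Nothing available explains why the amino and oxy links read alike.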